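A few compounds are considered here, and "the series" means these few. Any claim that something is new, unique, unknown or untested is made for them only; others in the source may bear on it.

Measured in an in vitro functional assay on RBL cells for antagonist activity at C-C chemokine receptor type 8 (Homo sapiens), read by FLIPR and calcium flux; a lower number here means a stronger inhibitor, a higher number a weaker inhibitor:
- compound 1 `COc1ccc2nccc(C3CN(CCCNCc4cc5ccccc5[nH]4)C(=O)O3)c2c1` gives 1580 nM
- compound 2 `O=C1OC(c2ccncc2)CN1C1CCN(Cc2cc3ccccc3[nH]2)CC1` gives < 50200 nM, a limit of this assay and not a number
- compound 3 `COc1ccc2nccc(C3CN(C4CCN(Cc5cc6ccccc6n5C)CC4)C(=O)O3)c2c1` gives 3160 nM

Compound 3 and compound 1 sit within the scatter of each other, so the two numbers cannot be ordered. Compound 2 is recorded only as a limit, with its value at the limit of < 50200 nM in this assay, at which 1 of the 3 values shown sits, so it adds no number to compare against. Among the compounds with values here, no step between measured compounds differs in a single place, so nothing in the set measures the swap that leads to compound 4.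

Compound 4 `COc1ccc2nccc(C3CN(C4CCN(Cc5cc6ccccc6s5)CC4)C(=O)O3)c2c1` differs from compound 3 by 1-benzothiophen-2-yl in place of 1-methyl-1H-indol-2-yl on a saturated chain carbon bound to an amine nitrogen in a ring. The change keeps one five-membered aromatic ring with a single hetero atom fused to a six-membered carbon ring, with no donor and one acceptor either way, and removes the methyl on the ring nitrogen together with that nitrogen. Within the data shown here, with no measured step of this kind to rest on, a move of a 1.1-fold lower number from compound 3 to compound 4 (0.02 log units; within the scatter) is expected, that is, none beyond the scatter. Compound 4 is therefore estimated at 3000 nM, with a range from 1000 nM to 10000 nM.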

Compound 4, half-maximal inhibitory concentration: 794 nM
The estimate for compound 4 lay 3.8-fold (0.58 log units) above the measured number; the measured number lies below the stated range.
By their numbers in this assay, from the lowest: compounds 4, 1 and 3 (each within the scatter of the next, the first and the last beyond it).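

In this assay, within the data shown here, 1-benzothiophen-2-yl in place of 1-methyl-1H-indol-2-yl on a saturated chain carbon bound to an amine nitrogen in a ring gives a 4.0-fold lower number from compound 3 to compound 4 (0.60 log units; beyond the scatter), the only measured step in the set that differs in one place. This position therefore responds to the choice of group, even though both groups have the same ring types and the same hydrogen-bond donor and acceptor counts. No measured property in the set bears on the size of this step.

The step replaces the methyl-bearing ring nitrogen with sulfur in one change, so the contributions of the methyl, the nitrogen and the sulfur remain unseparated; 1-benzofuran-2-yl or naphthalen-2-yl at this place would test the ring hetero atom. Going by these compounds, whether the same swap holds with the chain of compound 1 also remains open.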